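The source may report more compounds than this note shows. Statements on the series, on what has been measured and on what is new or still open speak of the compounds shown alone.

Measured so far in an assay for activation of potassium voltage-gated channel subfamily KQT member 1 (Cavia porcellus); on this read-out lower numbers stand for stronger inhibition and higher numbers for weaker inhibition:
- compound 1 `CCCCCCOc1ccc(C(=O)NC2CCCC2(C)C)cc1`: > 30000 nM
- compound 2 `CC(C)(C)CCNC(=O)c1ccc(-n2ccc3ccccc32)cc1`: 260 nM
- compound 3 `CCCc1noc(-c2ccc(C(=O)NCC3CCCC3(C)C)cc2)n1`: 27 nM; 10 nM (2 entries)

Three compounds have numbers or limits in this assay. For compound 1 the read-out is not a number but a limit of the assay, > 30000 nM. Compound 1 therefore stands at the weak end of everything shown, and it is the only one that sits there, as the limit of > 30000 nM in this assay, at which 1 of the 3 values shown sits, makes clear. Compound 3 has several entries, (the several entries of compound 3 in this assay, 27 nM; 10 nM (2 entries)), and they lie at the strong end of the shown values. Compound 2 gives 260 nM and lies between the two.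

The next compound to be measured is compound 4 `CCCCCCOc1ccc(C(=O)NC2CCC(C)(C)C2)cc1`. It shares the core of compound 1 and differs only in the ring on the amide nitrogen: 3,3-dimethylcyclopentyl in place of 2,2-dimethylcyclopentyl on an amide-type nitrogen. Going by the values given here, since no step between two measured compounds of this kind exists, the size of this step can only be guessed from the shape of the change, which keeps the same atoms and only moves the two methyl groups along the ring. The step from compound 1 to compound 4 a step that the limit leaves unreadable from compound 1 to compound 4 is expected to be small, most likely none beyond the scatter, so compound 4 is expected to remain near the limit of the assay. Compound 4 is estimated at 40000 nM, with a range from 10000 nM to 150000 nM.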

Compound 4, half-maximal inhibitory concentration: 360 nM
Estimate against measurement, compound 4: 110-fold (2.05 log units) above; the measured number lies below the stated range.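

In this assay, putting 3,3-dimethylcyclopentyl in place of 2,2-dimethylcyclopentyl on an amide-type nitrogen gives an at least 83-fold lower number from compound 1 to compound 4 (1.92 log units; beyond the scatter), so at this position the arrangement of the same carbon atoms matters, and not only which atoms are present. For compound 1 the read-out of > 30000 nM is a limit of the assay and not a number. Nothing shown here explains why moving the two methyl groups has so large an effect.

This single pair cannot show whether the step is specific to these two dimethylcyclopentyl groups, and it leaves open what a plain cyclopentyl with no methyl groups, or a cyclohexyl, would give on the same amide-type nitrogen. Compound 2 and compound 3 differ from compound 4 in more than one place, so they cannot show whether the 3,3-dimethylcyclopentyl group would have the same effect on another core.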